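The source may report more compounds than this note shows. Statements on the series, on what has been measured and on what is new or still open speak of the compounds shown alone.

Measured compounds:
compound 1 `Nc1nc(N/N=C/c2cccc(OCc3ccccc3)c2)nc2c1ncn2[C@@H]1O[C@H](CO)[C@@H](O)[C@H]1O`, which in an assay on CHO-K1 cells for displacement of a labelled ligand from adenosine receptor A1 (Homo sapiens), read by scintillation counting, with a stated time of 60 min (on this read-out higher numbers stand for weaker inhibition and lower numbers for stronger inhibition), gives 13 nM;
compound 2 `CCCCc1nc(/C=N/Nc2nc(N)c3ncn([C@@H]4O[C@H](CO)[C@@H](O)[C@H]4O)c3n2)c(Cl)[nH]1`, which in this assay gives 12 nM;
compound 3 `Nc1nc(N/N=C/c2ccc(-c3ccccc3)cc2)nc2c1ncn2[C@@H]1O[C@H](CO)[C@@H](O)[C@H]1O`, which in this assay gives 7860 nM.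

Compound 2 has the lowest of the three numbers, but its nearest neighbour, compound 1, lies within the scatter of it, so no order between the two can be claimed. Compound 3 stands far from both, beyond the scatter, and is the weakest of the set by a wide margin.

Compound 4 is `N#Cc1ccccc1/C=N/Nc1nc(N)c2ncn([C@@H]3O[C@H](CO)[C@@H](O)[C@H]3O)c2n1`. It differs from compound 2 in one place: 2-cyanophenyl in place of 2-butyl-5-chloro-1H-imidazol-4-yl on a carbon with a double bond to nitrogen. Going by the values given here, no step between measured compounds with this kind of change exists, so the expectation rests on the spread of the three numbers alone: a carbon-only ring in place of the five-membered ring carrying the donor, with the values of compound 1 and compound 3 showing that six-membered aromatic rings at this position can give either a low or a very high number. A step toward a higher number in this assay is expected, of moderate size, a 21-fold higher number from compound 2 to compound 4 (1.32 log units; beyond the scatter). For compound 4 the estimate is 250 nM, with a range from 25 nM to 2500 nM.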

Compound 4, inhibition constant: 2.9 nM
Estimate against measurement, compound 4: 86-fold (1.94 log units) above; measured number below the stated range.
By their numbers in this assay, from the lowest: compound 4; then compounds 2 and 1 (each within the scatter of the next); then compound 3.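

In this assay, going by these compounds alone, the change from 2-butyl-5-chloro-1H-imidazol-4-yl to 2-cyanophenyl on a carbon with a double bond to nitrogen gives a 4.1-fold lower number from compound 2 to compound 4 (0.62 log units; beyond the scatter) and is the first readable step at this position. It shows that a low number here does not depend on the five-membered aromatic ring or its hydrogen-bond donor, since a six-membered aromatic ring of carbon only, with 0 hydrogen-bond donors and a nitrile, goes lower still. No measurement at hand explains this step.

As far as these compounds go, what a plain phenyl would give at this position stays open, and so does the effect of an amine or a carboxylic acid in place of the nitrile. From the compounds shown here alone, it is also open how the imidazole would fare with a shorter chain in place of the butyl.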